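Benzyl for trifluoromethyl on the aromatic oxygen: compound 4 outlook

The source may hold more compounds than are shown below. What is called first, only, known or untested is meant among the compounds shown, and "the series" means these compounds.

Working notes on the nitroimidazole series. In an ADME assay on MRC5 cells (Homo sapiens) for cytotoxicity (on this read-out lower numbers stand for stronger inhibition and higher numbers for weaker inhibition), compound 1 `O=[N+]([O-])c1cn2c(n1)SCC(OCc1ccc(-c3ccc(OC(F)(F)F)cc3)cn1)C2` gives 21000 nM. Compound 2 `O=[N+]([O-])c1cn2c(n1)[S+]([O-])CC(OCc1ccc(-c3ccc(OC(F)(F)F)cc3)cn1)C2` gives 16000 nM; 54000 nM (2 entries) in this assay; the spread of its repeat entries, (the several entries of compound 2 in this assay, 16000 nM; 54000 nM (2 entries)), marks how loosely the read-out is known here. Compound 3 `O=[N+]([O-])c1cn2c(n1)SCC(OCc1ccc(OC(F)(F)F)cc1)C2` gives only a limit in this assay, > 64000 nM, and a further entry for compound 3 carries no single number. On the numbers shown, compound 3 therefore sits at the weak end of the set, at the limit described in the limit of > 64000 nM in this assay, at which 1 of the 3 values shown sits.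

Compound 4 `O=[N+]([O-])c1cn2c(n1)SCC(OCc1ccc(OCc3ccccc3)cc1)C2` is the next member. Against compound 3 the change is benzyl in place of trifluoromethyl on an oxygen on an aromatic ring. Going by the values given here, no pair of measured compounds differs in this one place, so the effect of the change has to be guessed. The step from compound 3 to compound 4 in this assay is expected to be small, an at least 1.6-fold lower number from compound 3 to compound 4 (0.20 log units; that floor lies within the scatter), with any movement toward stronger inhibition staying close to the scatter. Compound 4 is estimated at 40000 nM, within a range from 15000 nM to 90000 nM, with a fair chance that this assay again returns only a limit.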

Compound 4, half-maximal inhibitory concentration: > 64000 nM
Compound 4 ended at the assay's limit; the forecaster's own chance of this, stated with the estimate: 45%; middle value at least 1.6-fold (0.20 log units) away from the limit.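

No step from compound 3 to compound 4 can be read in this assay, because both values are limits of the assay: the limit of > 64000 nM in this assay, at which 2 of the 4 values shown sit.

The compounds shown leave open whether benzyl in place of trifluoromethyl on an oxygen on an aromatic ring changes the read-out at all.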